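Swapping a selenium chain end for amino

The source may report more compounds than this note shows. Statements on the series, on what has been measured and on what is new or still open speak of the compounds shown alone.

Measured in a functional assay on LoVo cells (Homo sapiens) for inhibition, read by MTT assay, with a stated time of 48 h; on this read-out lower numbers stand for stronger inhibition and higher numbers for weaker inhibition:
compound 1 `COc1ccc(N(C)c2nc(C)nc3ccccc23)cc1C(=O)OCC[Se]C#N`: 2960 nM
compound 2 `COc1ccc(N(C)c2nc(C)nc3ccccc23)cc1OCC[Se]C#N`: 19 nM
compound 3 `C[Se]c1ccc(N(C)c2nc(C)nc3ccccc23)cc1Cl`: 3 nM

In this assay compound 2 gives 19 nM and so stands second highest of the three numbers, with compound 3 lower and compound 1 far higher. Compound 4 `COc1ccc(N(C)c2nc(C)nc3ccccc23)cc1OCCN` has not yet been measured. Its structure departs from that of compound 2 in one place: one nitrogen atom in place of a group of 3 heavy atoms (1 carbon, 1 nitrogen, 1 selenium; no ring), on a saturated chain carbon, two bonds along the chain from an oxygen on an aromatic ring.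

Within the data shown here, only one measured step bears on this change. It is a 160-fold lower number from compound 1 to compound 2 (2.19 log units; beyond the scatter), which is large and shows that the number can move strongly when the chain on the aromatic carbon changes. That step keeps the selenium, however, and all three measured compounds carry selenium, so the data do not show what its loss does. A moderate move towards weaker inhibition is expected, with wide uncertainty. The estimated step is a 3.2-fold higher number from compound 2 to compound 4 (0.50 log units; beyond the scatter) in this assay. For compound 4 the estimated value is 60 nM, with an expected range from 8 nM to 450 nM.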

Compound 4, half-maximal inhibitory concentration: 421 nM
The estimate for compound 4 lay 7.0-fold (0.85 log units) below the measured number; the range from low to high includes it.
By their numbers in this assay, from the lowest: compound 3; then compound 2; then compound 4; then compound 1.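

Among these compounds, the first measured change at this chain end without selenium is large: in this assay, replacing the selenium-bearing end with amino gives a 22-fold higher number from compound 2 to compound 4 (1.35 log units; beyond the scatter). Compound 4 nevertheless does not fall to the level of the ester-linked selenium compound, with a 7.0-fold lower number from compound 1 to compound 4 (0.85 log units; beyond the scatter), so a chain without selenium can still give a lower number than that selenium compound. No supporting evidence is available to explain either step.

The step from compound 2 to compound 4 removes selenium and the nitrile together, and the compounds shown do not separate the two. On these data alone, how a hydroxyl, a thiocyanate or a longer chain ending in an amine would read at this position in this assay also remains open.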